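The source may report more compounds than this note shows. Statements on the series, on what has been measured and on what is new or still open speak of the compounds shown alone.

Of the compounds shown here, two have been read so far in a functional assay on HCT-116 cells (Homo sapiens) for cytotoxicity, read by MTT assay, with a stated time of 72 h; on this read-out lower numbers stand for stronger inhibition and higher numbers for weaker inhibition. In this assay compound 1, `CS(=O)(=O)Oc1c(C(=O)NCc2ccc(F)cc2)nc(Br)c2cccnc12`, gives > 20000 nM, which is a limit of the assay and not a number. In the same test compound 2, `O=C(NCc1ccc(F)cc1)c1nc(Br)c2cccnc2c1NCCCNc1c(C(=O)NCc2ccc(F)cc2)nc(Br)c2cccnc12`, gives > 20000 nM, and this too is a limit. Compound 1 therefore stands at the limit of > 20000 nM in this assay, at which 2 of the 2 values shown sit.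

The next compound to be tested is compound 3, `Nc1ccc(Nc2c(C(=O)NCc3ccc(F)cc3)nc(Br)c3cccnc23)cc1`. It differs from compound 1 in one place, where (4-aminophenyl)amino stands in place of (methylsulfonyl)oxy on an aromatic carbon, para to a bromo group: (4-aminophenyl)amino in place of (methylsulfonyl)oxy on an aromatic carbon.

Among the measured compounds shown here, no measured pair shows what a change at this carbon does, so any forecast of the step is rough. A moderate move toward stronger inhibition is expected, although compound 3 may well stay at the limit too. The expected change is an at least 2.5-fold lower number from compound 1 to compound 3 (0.39 log units; beyond the scatter). For compound 3 the estimated value is 8000 nM, with an expected range from 2000 nM to 20000 nM.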

Compound 3, half-maximal inhibitory concentration: 7000 nM
The estimate for compound 3 lay 1.1-fold (0.06 log units) above the measured number; low and high end bracket the measured number.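

In this assay, compound 3 gives the first number shown rather than a limit, so a change at this aromatic carbon, para to a bromo group, can now be seen to alter the read-out. Putting (4-aminophenyl)amino in place of (methylsulfonyl)oxy gives an at least 2.8-fold lower number from compound 1 to compound 3 (0.45 log units; beyond the scatter), and the entering group brings an aromatic ring of carbon only and hydrogen-bond donors that the leaving group lacks. The step gives only a minimum size and not an exact one, and the limit still dominates the values shown: the limit of > 20000 nM in this assay, at which 2 of the 3 values shown sit.

The compounds shown do not tell whether the change comes from the linking nitrogen, the aromatic ring or the amino group on that ring, and a plain phenylamino group or a morpholine at this carbon would help to separate these parts. From the compounds shown here alone, it also remains open whether a step of this size would hold on other cell types, as every value here comes from this assay.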